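The compounds below may be only part of what the source reports. "The series", "measured", "known", "first", "only" and "open" are said of these compounds alone.

In a functional assay on MCF cells (Homo sapiens) for antiproliferative activity, with a stated time of 72 h (a higher number here means a weaker inhibitor, a lower number a stronger inhibitor), compound 1, `OC[C@H]1O[C@@H](n2cnc3c(NCc4cccc(F)c4)ncnc32)[C@H](O)[C@@H]1O`, gives 15300 nM. Compound 2, `OC[C@H]1O[C@@H](n2cnc3c(NCc4ccccc4Br)ncnc32)[C@H](O)[C@@H]1O`, is reported only as a limit, > 166000 nM. Compound 3, `OC[C@H]1O[C@@H](n2cnc3c(NCc4ccc(F)c(F)c4F)ncnc32)[C@H](O)[C@@H]1O`, is also reported only as a limit, > 166000 nM. Compound 3 thus stands at the limit of > 166000 nM in this assay, at which 2 of the 3 values shown sit, and no number is known for it.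

The next structure is compound 4, `Cc1ccc(O)c(CNc2ncnc3c2ncn3[C@@H]2O[C@H](CO)[C@@H](O)[C@H]2O)c1`, which carries 2-hydroxy-5-methylphenyl in place of 2,3,4-trifluorophenyl on a saturated chain carbon bound to a nitrogen on an aromatic ring.

Among the measured compounds shown here, three measured steps bear on this change. Two are large: an at least 10-fold higher number from compound 1 to compound 2 (1.03 log units; beyond the scatter), and an at least 10-fold higher number from compound 1 to compound 3 (1.03 log units; beyond the scatter). The third, a step that the two limits leave unreadable from compound 2 to compound 3, cannot be read. Among these three compounds, the two whose group names carry a substituent at position 2 both sit at the limit. Compound 1, which has a 3-fluorophenyl group, gives 15300 nM. Compound 4 also carries a group at position 2, although neither its hydroxy nor its methyl group has been tested in this series.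

It is therefore expected to remain weak in this assay, and it may again return only a limit. The expected step, toward a lower number and modest in size, is an at least 1.8-fold lower number from compound 3 to compound 4 (0.26 log units; that floor lies within the scatter). For compound 4 the estimated value is 90000 nM, with an expected range from 20000 nM to 250000 nM.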

Compound 4, half-maximal inhibitory concentration: > 166000 nM
Compound 4 ended at the assay's limit (the forecaster's own chance of this, stated with the estimate: 50%); middle value at least 1.8-fold (0.26 log units) away from the limit.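

In this assay, placing 2-hydroxy-5-methylphenyl on a saturated chain carbon bound to a nitrogen on an aromatic ring gives an at least 10-fold higher number from compound 1 to compound 4 (1.03 log units; beyond the scatter). The entering group has a hydrogen-bond donor and a hydrogen-bond acceptor, where 2,3,4-trifluorophenyl has none, yet compound 4 joins compound 2 and compound 3: the limit of > 166000 nM in this assay, at which 3 of the 4 values shown sit. So the link between a group numbered at position 2 and a result at the limit now extends from halogen-only rings to one bearing hydroxy and methyl groups, and none of the compounds shown goes against it, with compound 1 alone giving a number.

The steps among compound 2, compound 3 and compound 4 cannot be read, so any order among these three remains unknown. It also remains open whether the loss follows the substituent at position 2 or the particular groups shown, a question that 2-fluorophenyl, 3-hydroxyphenyl or unsubstituted phenyl at this place could help to settle.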